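The compounds below may be only part of what the source reports. "The series", "measured", "known", "first", "only" and "open" are said of these compounds alone.

Compound 2 `C=CC1=C(C(=O)NC2CCCCC2)C(c2ccc(OC)c(OC)c2)OC1` gives 5540 nM in a functional assay on HeLa cells (Homo sapiens) for cytotoxicity, read by MTT assay, with a stated time of 24 h (a lower number here means a stronger inhibitor, a higher number a weaker inhibitor), the lowest of the two numbers shown. Compound 3 `C=CC1=C(C(=O)NC2CCCCC2)C(c2ccc(OC)cc2)OC1` gives 24800 nM in this assay, and the step of a 4.5-fold higher number from compound 2 to compound 3 (0.65 log units; beyond the scatter) is the only measured one. Compound 1 `C=CC1=C(C(=O)NCCC)C(c2ccc(F)cc2)OC1` gives only a limit, > 100000 nM (the limit of > 100000 nM in this assay, at which 1 of the 3 values shown sits), in this assay. Compound 4 `C=CC1=C(C(=O)NCc2ccc(C)cc2)C(c2ccc(OC)c(OC)c2)OC1` differs from compound 2 by 4-methylbenzyl in place of cyclohexyl on an amide-type nitrogen. Among the compounds with values here, no measured step touches the amide nitrogen: the step from compound 2 to compound 3 concerns the aromatic ring, and compound 1 differs from compound 2 in two places. The change is therefore expected to give no step beyond the scatter, a 1.1-fold higher number from compound 2 to compound 4 (0.03 log units; within the scatter), with a wide margin. Compound 4 is estimated at 6000 nM, between 1500 nM and 30000 nM.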

Compound 4, half-maximal inhibitory concentration: > 100000 nM
Compound 4 gave a limit, no number; the forecaster's own chance of this, stated with the estimate: 10%; middle value at least 16-fold (1.22 log units) from the limit.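

The amide nitrogen now has a measured step in this assay: 4-methylbenzyl in place of cyclohexyl gives an at least 18-fold higher number from compound 2 to compound 4 (1.25 log units; beyond the scatter), so this position is not neutral, which the earlier step on the aromatic ring could not show. Among the compounds shown, cyclohexyl is the only group on that nitrogen with a number rather than a limit. Compound 4 gives a limit, so the full size of the step stays unknown: the limit of > 100000 nM in this assay, at which 2 of the 4 values shown sit.

Still open, from the compounds shown here alone, is whether plain benzyl, cyclopentyl or a hydroxyethyl chain on that nitrogen would give a number in this assay. The compounds shown also do not separate the aromatic ring of 4-methylbenzyl from its methyl group.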